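A Carbamate Added to an Inactive Starting Point

The compounds below may be only part of what the source reports. "The series", "measured", "known", "first", "only" and "open" are said of these compounds alone.

Of the compounds shown here, three have been tested in a functional assay on cells (Splenocyte, Mus musculus, strain BALB/c) for inhibition, read by scintillation counting and thymidine incorporation, with stated times of 48 h and 8 h; a higher number here means a weaker inhibitor, a lower number a stronger inhibitor. Compound 1 `Clc1ccc(-c2noc(Cc3c[nH]c4ccccc34)n2)cc1` returns only a limit of the assay, > 50000 nM. Compound 2 `COc1cc(OC)cc(-c2nc(Cc3c[nH]c4ccccc34)no2)c1` gives a measured half-maximal inhibitory concentration of 13900 nM in this assay. Compound 3 `COc1cc(-c2noc(-c3ccccc3)n2)cc(OC)c1OC` likewise returns only a limit, > 50000 nM. Compound 3 thus stands where most of the series stands: the limit of > 50000 nM in this assay, at which 2 of the 3 values shown sit, and only compound 2 yields a number at all. Compound 4 `COc1cc(-c2noc(-c3ccc(NC(=O)OC(C)(C)C)cc3)n2)cc(OC)c1OC` has not yet been measured in this assay. It differs from compound 3 in one place: (tert-butoxycarbonyl)amino in place of hydrogen on an aromatic carbon. Among the measured compounds shown here, no two measured compounds differ in a single place, so no measured step shows how large a change of this kind can be. The step expected for an at least 1.2-fold lower number from compound 3 to compound 4 (0.09 log units; that floor lies within the scatter) is therefore small, most likely no change beyond the scatter, with a modest gain possible but not assured. Compound 4 is expected to give about 40000 nM, in the range 10000 nM to 100000 nM, and a fair chance remains that it returns only a limit again.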

Compound 4, half-maximal inhibitory concentration: 2200 nM
Beside the measured number, compound 4's estimate is 18-fold (1.26 log units) above it; the measured number lies below the stated range.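

In this assay, (tert-butoxycarbonyl)amino in place of hydrogen on an aromatic carbon, para to a large group, brings an at least 22-fold lower number from compound 3 to compound 4 (1.35 log units; beyond the scatter). Among the compounds shown here, this is the first single-place step, and it shows that this position of the six-membered aromatic ring can take a substituent and that one change there can turn an assay limit into a measured number. The true size of the step remains unknown, and the printed figure is only a floor, because the starting point is itself a limit: the limit of > 50000 nM in this assay, at which 2 of the 4 values shown sit.

With a single group at this position, the compounds shown cannot say which part of it matters. On these data alone, whether a free amine, an acetamide or a methyl carbamate in the same place would give a similar number remains open.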